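The compounds below may be only part of what the source reports. "The series", "measured", "known", "first", "only" and "open" are said of these compounds alone.

Measured so far in a functional assay on PC-3 cells (Homo sapiens) for antiproliferative activity, read by MTT assay, with a stated time of 12 h; a higher number here means a weaker inhibitor, a lower number a stronger inhibitor:

compound 1 `COc1cc(OC)c2c(=O)cc(/C=C/c3ccc(Cl)cc3)oc2c1`, > 40000 nM.
compound 2 `O=c1cc(/C=C/c2ccc(OC(F)(F)F)cc2)oc2ccccc12`, 28900 nM.
compound 3 `COc1cc(/C=C/c2cc(=O)c3c(OC)cc(OC)cc3o2)cc(OC)c1`, > 40000 nM.

The result of compound 1 in this assay is a limit, not a number. Compound 1 therefore sits at the limit of > 40000 nM in this assay, at which 2 of the 3 values shown sit. Compound 2 is the only one of the three with a number in this assay, and it is a weak one.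

Compound 4 `COc1cc(OC)c2c(=O)cc(/C=C/c3ccc(F)cc3)oc2c1` has not yet been measured. It differs from compound 1 by fluoro in place of chloro on an aromatic carbon. Going by the values given here, no pair of measured compounds shares this change, so there is no measured step to lean on. The expectation is a step of no more than the scatter, in either direction, so compound 4 is estimated at 50000 nM, within 15000 nM to 150000 nM, an expected step that the limit leaves unreadable from compound 1 to compound 4.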

Compound 4, half-maximal inhibitory concentration: > 40000 nM
Compound 4: only a limit was reported; the forecaster's own chance of this, stated with the estimate: 70%; the middle value is on the limit's open side.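

Compound 1 and compound 4 each have only a limit in this assay, not a number, so no step can be read between them. The compounds shown leave open whether fluoro in place of chloro changes activity at all.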